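The compounds below may be only part of what the source reports. "The series", "measured", "known", "first", "only" and "open" are said of these compounds alone.

Working notes on the series in a functional assay on LOX IMVI cells (Homo sapiens) for inhibition, read by sulforhodamine B assay, with a stated time of 48 h, tested at 10 uM; on this read-out higher numbers stand for more inhibition at the one concentration tested (going by the name of the read-out) and lower numbers for less inhibition. Compound 1 `c1ccc(-c2cn3ccnc3c(-c3ccc4ncn(C5CCCCC5)c4c3)n2)cc1` gives 39.6%. Compound 2 `O=Cc1ccc(-c2cn3ccnc3c(-c3ccc4ncn(C5CCCCC5)c4c3)n2)cc1` carries formyl in place of hydrogen on an aromatic carbon, and compound 2 gives 46.9%; the step is a number 7.3 percentage points higher from compound 1 to compound 2 (within the scatter). Compound 3 `c1ccc2c(-c3cn4ccnc4c(-c4ccc5ncn(C6CCCCC6)c5c4)n3)cccc2c1` gives 7.43%, the lowest of the three numbers; its steps are a number 32.2 percentage points lower from compound 1 to compound 3 (beyond the scatter) and a number 39.5 percentage points lower from compound 2 to compound 3 (beyond the scatter), both of them large.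

Compound 4 `Fc1ccc(-c2cn3ccnc3c(-c3ccc4ncn(C5CCCCC5)c4c3)n2)cc1` differs from compound 3 by 4-fluorophenyl in place of naphthalen-1-yl on an aromatic carbon. The step that bears most directly on this change is a number 32.2 percentage points lower from compound 1 to compound 3 (beyond the scatter), since compound 4 reverses that exchange of naphthalen-1-yl for a phenyl, here a 4-fluorophenyl. Whether a substituted phenyl behaves differently from a bare phenyl is shown by a number 7.3 percentage points higher from compound 1 to compound 2 (within the scatter), which stayed within the scatter, so compound 1 and compound 2 give no reason to expect the fluorine to move the number far. The expectation for compound 4 in this assay is therefore a large rise from compound 3, back toward the numbers of compound 1 and compound 2. Compound 4 is estimated at 40%, with a range of 25% to 55%. The expected step is a number 32.6 percentage points higher from compound 3 to compound 4 (beyond the scatter).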

Compound 4, a percentage reported as inhibition, at one concentration (the size of the read-out at that concentration, not a potency): 3.5%
Estimate against measurement, compound 4: 36.5 percentage points above; measured number outside the range, below it.
By their numbers in this assay, from the lowest: compounds 4 and 3 (each within the scatter of the next); then compounds 1 and 2 (each within the scatter of the next).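

In this assay, the substituent on the phenyl at this position matters more than compound 1 and compound 2 suggested: fluoro in place of hydrogen gives a number 36.1 percentage points lower from compound 1 to compound 4 (beyond the scatter) and fluoro in place of formyl gives a number 43.4 percentage points lower from compound 2 to compound 4 (beyond the scatter), so a single substituent on this phenyl can carry a large step, as the exchange of phenyl for naphthalen-1-yl did. The change from naphthalen-1-yl to 4-fluorophenyl gives a number 3.9 percentage points lower from compound 3 to compound 4 (within the scatter), so the smaller group with one aromatic ring does not separate from the larger group with two, and the low number of compound 3 cannot be tied to naphthalen-1-yl alone. No measurement at hand gives a reason for these steps.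

Going by these compounds, with only hydrogen, formyl and fluoro on this phenyl, it remains open whether the large step belongs to fluoro alone or would recur with chloro, methoxy or an amine in the same place. On these data alone, it also remains open whether a carboxylic acid or a nitrile there would stay with compound 1 and compound 2 or fall with compound 4.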